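This account rests on a few compounds, and the source may have more. Where it says the series, first, only, none or still open, it means among the compounds named here.

Notes on the series. Compound 1 is `O=C(CSc1nnnn1-c1cccc2ccccc12)N/N=C/c1ccc([N+](=O)[O-])cc1`. In an ADME assay on MT4 cells (Homo sapiens) for cytotoxicity, read by MTT assay (on this read-out higher numbers stand for lower toxicity in this test and lower numbers for higher toxicity in this test), compound 1 gives >= 260000 nM, which is a limit of the assay and not a number. Compound 2 is `COc1ccc(/C=N/NC(=O)CSc2nnnn2-c2cccc3ccccc23)cc1`, differing from compound 1 only in a methoxy in place of nitro on an aromatic carbon. In this assay compound 2 gives > 298000 nM, again a limit of the assay. Going by the values given here, the single measured step, a step that the two limits leave unreadable from compound 1 to compound 2, is therefore unreadable in size. Compound 2 stands at a limit, and the other value shown is also a limit (the limit of > 298000 nM in this assay, at which 1 of the 2 values shown sits, (the limit of >= 260000 nM in this assay, at which 1 of the 2 values shown sits)), so no ranking of the two is possible. Compound 3 is `O=C(CSc1nnnn1-c1cccc2ccccc12)N/N=C/c1ccccc1`; it differs from compound 2 as follows: hydrogen in place of methoxy on an aromatic carbon. Among the compounds with values here, no measured step reads out on this change. Both measured compounds sit at limits, so compound 3 is expected to sit at a limit as well; the expected step is a step that the limit leaves unreadable from compound 2 to compound 3, none beyond the scatter. Compound 3 is thus estimated at 300000 nM, within 150000 nM to 600000 nM.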

Compound 3, half-maximal cytotoxic concentration: 216000 nM
Compound 3: the middle estimate sits 1.4-fold (0.14 log units) above what was measured, and the stated range covers the measured number.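

Going by these compounds alone, compound 3 is the first compound to give a number rather than a limit in this assay, which makes the position para to a large group readable at least from one side. Hydrogen in place of methoxy gives an at least 1.3-fold lower number from compound 2 to compound 3 (0.13 log units; that floor lies within the scatter), and hydrogen in place of nitro gives an at least 1.2-fold lower number from compound 1 to compound 3 (0.08 log units; that floor lies within the scatter). Both steps start from a limit of the assay, so they give only floors that do not set compound 3 apart from the substituted compounds, and the steps between the two limits still cannot be read.

On these data alone, it remains open how far the true values of compound 1 and compound 2 lie from their limits. Also open, as far as these compounds go, is whether an amine or a carboxylic acid at this place on the ring would give a step beyond the scatter.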